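The source may hold more compounds than are shown below. What is called first, only, known or untested is meant among the compounds shown, and "the series" means these compounds.

Measured compounds in a functional assay on HeLa cells (Homo sapiens) for inhibition, read by trypan blue exclusion, with a stated time of 72 h; a higher number here means a weaker inhibitor of growth, a lower number a stronger inhibitor of growth:

Compound 1 `CC/C(=C(/c1ccc(NC(=O)C(C)C)cc1)c1ccc(OC)cc1)c1ccccc1` gives > 30000 nM in this assay, which is a limit and not a number.
Compound 2 `CC/C(=C(/c1ccc(NC(=O)C(C)C)cc1)c1ccc(OC)cc1)c1ccc(Cl)cc1Cl` gives 2200 nM in this assay.
Compound 3 `CC/C(=C(/c1ccc(O)cc1)c1ccc(NC(=O)C(C)C)cc1)c1ccccc1` gives 9900 nM in this assay.

Compound 1 and compound 2 share a core and differ in one place: 2,4-dichlorophenyl in place of phenyl on a double-bonded chain carbon bound to a double-bonded chain carbon and a saturated chain carbon. This change gives an at least 13-fold lower number from compound 1 to compound 2 (1.13 log units; beyond the scatter); the step can only be stated as a lower bound because of the limit of > 30000 nM in this assay, at which 1 of the 3 values shown sits. The core of compound 3 differs from the core of compound 1, but that difference is not broken down here; compound 3 stands as the highest of the two numbers shown.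

Compound 4 `CC/C(=C(/c1ccc(O)cc1)c1ccc(NC(=O)C(C)C)cc1)c1ccc(Cl)cc1Cl` is not yet measured. It is built from compound 3 by the same change: 2,4-dichlorophenyl in place of phenyl on a double-bonded chain carbon bound to a double-bonded chain carbon and a saturated chain carbon. The place of the change is the same in both pairs. On the basis of the step from compound 1 to compound 2 an at least 13-fold lower number from compound 1 to compound 2 (1.13 log units; beyond the scatter), a step of similar size is expected, an 11-fold lower number from compound 3 to compound 4 (1.04 log units; beyond the scatter). Compound 4 is therefore expected to give roughly 900 nM in this assay, estimated to lie between 300 nM and 3000 nM.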

Compound 4, concentration for 50% growth inhibition: 20300 nM
Estimate against measurement, compound 4: 23-fold (1.35 log units) below; measured number above the stated range.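

In this assay, 2,4-dichlorophenyl in place of phenyl on the core of compound 3 gives a 2.1-fold higher number from compound 3 to compound 4 (0.31 log units; beyond the scatter), so the stronger growth inhibition seen with this change on the core of compound 1 does not carry over. The same change runs in opposite directions on the two cores, but this rests on one pair per core and does not show which feature of the core sets the direction: the same change on two cores in this assay, an at least 13-fold lower number (1.13 log units; beyond the scatter) from compound 1 to compound 2 and a 2.1-fold higher number (0.31 log units; beyond the scatter) from compound 3 to compound 4, at least 27-fold (1.44 log units) apart, beyond the scatter of two such steps
Compound 1 gives > 30000 nM, which is a limit of the assay and not a number, so the step on that core has a bound and no exact size.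

As far as these compounds go, it remains open which part of the difference between the two cores decides the direction of the step, and whether the reversal holds on any further core. Also open, from the compounds shown here alone, is how the change behaves with a longer chain on the amide carbonyl, or with an amine in place of the hydroxyl group of compound 3 and compound 4.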